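Propyl to Cyclopentyl on the Amide Nitrogen

A few compounds are considered here, and "the series" means these few. Any claim that something is new, unique, unknown or untested is made for them only; others in the source may bear on it.

Measured compounds:
compound 1 `CC[C@@H]1C(=O)N(C)c2cnc(-n3ccc4cc(C(=O)NC(C)C)ccc43)nc2N1C1CCCC1`: 17.4 nM
compound 2 `CCCNC(=O)c1ccc2c(ccn2-c2ncc3c(n2)N(C2CCCC2)[C@H](CC)C(=O)N3C)c1`: 11.4 nM

In an assay for inhibition of serine/threonine-protein kinase PLK2 (Homo sapiens), read by FRET and Z'-LYTE, with a stated time of 1 h (a higher number here means a weaker inhibitor, a lower number a stronger inhibitor), compound 2 gives 11.4 nM, and compound 1 gives 17.4 nM. Among the measured compounds shown here, the only change between them, a 1.5-fold lower number from compound 1 to compound 2 (0.18 log units; within the scatter), stays within the scatter, so the two compounds cannot be told apart on these numbers; compound 2 simply carries the smaller of the two values.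

Compound 3 `CC[C@@H]1C(=O)N(C)c2cnc(-n3ccc4cc(C(=O)NC5CCCC5)ccc43)nc2N1C1CCCC1` has not yet been measured. It differs from compound 2 by cyclopentyl in place of propyl on an amide-type nitrogen. For the measured compounds named here, the one step that bears on this, a 1.5-fold lower number from compound 1 to compound 2 (0.18 log units; within the scatter), shows that exchanging one small alkyl group on this amide-type nitrogen for another left the result within the scatter. By that single comparison, compound 3 is expected to show a 1.1-fold higher number from compound 2 to compound 3 (0.06 log units; within the scatter), with no shift beyond the scatter. The estimate for compound 3 in this assay is therefore 13 nM, with a range from 5 nM to 35 nM.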

Compound 3, half-maximal inhibitory concentration: 7.06 nM
The estimate for compound 3 lay 1.8-fold (0.27 log units) above the measured number; the measured number falls inside the stated range.
By their numbers in this assay, from the lowest: compounds 3, 2 and 1 (each within the scatter of the next, the first and the last beyond it).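

In this assay, among the compounds shown here, a ring can stand on this amide-type nitrogen without loss: cyclopentyl in place of propyl gives a 1.6-fold lower number from compound 2 to compound 3 (0.21 log units; within the scatter) and so cannot be told apart from the open chain, while cyclopentyl in place of isopropyl gives a 2.5-fold lower number from compound 1 to compound 3 (0.39 log units; beyond the scatter) and is the first step at this position to pass beyond the scatter, though only modestly. Compound 3 therefore separates from compound 1 but not from compound 2, so the data show no clear advantage of the ring over every open chain. Nothing measured here accounts for these differences.

From the compounds shown here alone, whether cyclopropyl, cyclohexyl or a longer chain such as butyl would separate from compound 3 remains open. So does the effect of an amine or a hydroxyl group on the cyclopentyl ring.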